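Varying the pyrrolidine acyl group in a sulfonamide series

A few compounds are considered here, and "the series" means these few. Any claim that something is new, unique, unknown or untested is made for them only; others in the source may bear on it.

Compound 1 `CN(C)CC(=O)N1CCC(NS(=O)(=O)c2cc(S(=O)(=O)c3ccccc3)ccc2C(F)(F)F)CC1`: 300 nM
Compound 2 `CC(C)(C)OC(=O)N1CCC[C@@H]1C(=O)N1CCC(NS(=O)(=O)c2cc(S(=O)(=O)c3ccccc3)ccc2C(F)(F)F)CC1`: 120 nM
Compound 3 `CC(C)(C)CC(=O)N1CCC[C@H]1C(=O)N1CCC(NS(=O)(=O)c2cc(S(=O)(=O)c3ccccc3)ccc2C(F)(F)F)CC1`: 20 nM

In an assay on isolated protein for binding affinity to secreted frizzled-related protein 1 (Homo sapiens), read by fluorescence (a higher number here means a weaker inhibitor, a lower number a stronger inhibitor), compound 2 stands second highest of the three numbers, with compound 1 nearest at a 2.5-fold lower number from compound 1 to compound 2 (0.40 log units; beyond the scatter) and compound 3 furthest at a 6.0-fold lower number from compound 2 to compound 3 (0.78 log units; beyond the scatter). Compound 4 `CN(C)CC(=O)N1CCC[C@H]1C(=O)N1CCC(NS(=O)(=O)c2cc(S(=O)(=O)c3ccccc3)ccc2C(F)(F)F)CC1` differs from compound 2 by 1-(((dimethylamino)methyl)carbonyl)pyrrolidin-2-yl in place of 1-(tert-butoxycarbonyl)pyrrolidin-2-yl on a carbonyl carbon. The step that bears most on this change is the exchange at the same position in a 6.0-fold lower number from compound 2 to compound 3 (0.78 log units; beyond the scatter), where a carbon-based acyl group gave a modest gain; the other relevant comparison, a 15-fold lower number from compound 1 to compound 3 (1.18 log units; beyond the scatter), shows the neopentylcarbonyl-pyrrolidine well ahead of the plain dimethylaminoacetyl group. Compound 4 is therefore expected to give a small step, estimated as a 1.5-fold lower number from compound 2 to compound 4 (0.18 log units; within the scatter), in this assay, with a value of 80 nM expected for compound 4 between 25 nM and 250 nM.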

Compound 4, half-maximal inhibitory concentration: 90 nM
The estimate for compound 4 lay 1.1-fold (0.05 log units) below the measured number, and the stated range covers the measured number.
By their numbers in this assay, from the lowest: compound 3; then compounds 4 and 2 (each within the scatter of the next); then compound 1.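

Placing 1-(((dimethylamino)methyl)carbonyl)pyrrolidin-2-yl where 1-(tert-butoxycarbonyl)pyrrolidin-2-yl stood gave no change beyond the scatter (a 1.3-fold lower number from compound 2 to compound 4 (0.12 log units; within the scatter)), while the pyrrolidine-bearing group also outperformed the plain (dimethylamino)methyl group (a 3.3-fold lower number from compound 1 to compound 4 (0.52 log units; beyond the scatter)). With the pyrrolidine kept, dimethylamino in place of tert-butyl on the saturated chain carbon cost affinity (a 4.5-fold higher number from compound 3 to compound 4 (0.65 log units; beyond the scatter)), so the end of this acyl chain still counts. No measured evidence accounts for these differences. Going by these compounds, whether a carboxylic acid or a longer alkyl chain at that chain carbon would match or pass compound 3 remains open.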